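The compounds below may be only part of what the source reports. "The series", "measured", "known", "first", "only" and "open" are said of these compounds alone.

In a functional assay on HeLa cells (Homo sapiens) for antiproliferative activity, read by MTT assay, with a stated time of 72 h (a higher number here means a weaker inhibitor, a lower number a stronger inhibitor), compound 1 `O=C1COc2ccc(-c3cnc(Cl)c(NS(=O)(=O)c4ccc(F)cc4)c3)cc2N1` gives 15600 nM. Compound 2 `O=C1COc2ccc(-c3cccc(NS(=O)(=O)c4ccc(F)cc4)c3)cc2N1c1ccc(Cl)cc1` gives 35000 nM, the higher of the two numbers and so the weaker result, by a gap beyond the usual scatter. Compound 3 `Cc1ccc(N2C(=O)COc3ccc(-c4cccc(NS(=O)(=O)c5ccc(F)cc5)c4)cc32)cc1` has not yet been measured. It differs from compound 2 by a single swap, methyl in place of chloro on an aromatic carbon, turning 4-chlorophenyl into 4-methylphenyl. Among the measured compounds shown here, no measured step of this kind is available, so no change beyond the scatter is expected in this assay, and the estimated step is a 1.2-fold lower number from compound 2 to compound 3 (0.07 log units; within the scatter). The expected value for compound 3 is 30000 nM, with an estimated range of 12000 nM to 75000 nM.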

Compound 3, half-maximal inhibitory concentration: > 40000 nM
Compound 3: only a limit was reported; the forecaster's own chance of this, stated with the estimate: 15%; middle value at least 1.3-fold (0.12 log units) away from the limit.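

In this assay compound 3 gives > 40000 nM as a limit of the assay and not a number. Going from 4-chlorophenyl to 4-methylphenyl gives an at least 1.1-fold higher number from compound 2 to compound 3 (0.05 log units; that floor lies within the scatter) and so brings no gain at this position, though whether methyl costs anything stays unread, since the reading stops at a limit: the limit of > 40000 nM in this assay, at which 1 of the 3 values shown sits.

Going by these compounds, whether any group in this place can lower the number remains open. A methoxy group, an amine or a carboxylic acid on the same aromatic carbon would test this.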